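Methoxy for chloro: does the step repeat on another core?

The source may report more compounds than this note shows. Statements on the series, on what has been measured and on what is new or still open speak of the compounds shown alone.

Of the compounds shown here, three have been measured in a functional assay on cells (Cancer cell lines, Homo sapiens) for cytotoxicity, with a stated time of 48 h; a higher number here means a weaker inhibitor of growth, a lower number a stronger inhibitor of growth: compound 1 `COc1cc2c(/C=C3/C(=O)Nc4ccc(Cl)cc43)c(Cl)n(Cc3cc(OC)c(OC)c(OC)c3)c2cc1C` gives 2950 nM, compound 2 `COc1ccc2c(c1)/C(=C\c1c(Cl)n(Cc3cc(OC)c(OC)c(OC)c3)c3cc(C)c(OC)cc13)C(=O)N2` gives 29500 nM, and compound 3 `COc1c(/C=C2/C(=O)Nc3ccc(Cl)cc32)c2ccccc2n1-c1ccccc1` gives 8510 nM.

Compound 1 and compound 2 differ in one place, (methoxy in place of chloro on an aromatic carbon), and that change brought a 10-fold higher number from compound 1 to compound 2 (1.00 log units; beyond the scatter). Compound 3 keeps the chloro of compound 1 but sits on a different core; how the two cores differ is not broken down here. In this assay compound 3 lands between the other two, a weaker growth inhibitor than compound 1 and a stronger one than compound 2.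

Compound 4 `COc1ccc2c(c1)/C(=C\c1c(OC)n(-c3ccccc3)c3ccccc13)C(=O)N2` has not yet been measured. Among the compounds with values here, it arises from compound 3 by methoxy in place of chloro on an aromatic carbon, the same change at the same place as the one from compound 1 to compound 2. Resting on that single measured pair, the expected step in this assay is a 7.1-fold higher number from compound 3 to compound 4 (0.85 log units; beyond the scatter), set beside a 10-fold higher number from compound 1 to compound 2 (1.00 log units; beyond the scatter). Within the data shown here, only one example of the change is known, and the core is different, so the bounds are kept wide. Compound 4 is therefore estimated to give about 60000 nM, expected to fall between 15000 nM and 200000 nM.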

Compound 4, concentration for 50% growth inhibition: 2290 nM
For compound 4 the middle estimate is 26-fold (1.42 log units) above the measured one; measured number below the stated range.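

In this assay, putting methoxy in place of chloro did not act the same way on both cores: on the core of compound 3 it gave a 3.7-fold lower number from compound 3 to compound 4 (0.57 log units; beyond the scatter), so the compound became a stronger growth inhibitor, whereas on the core of compound 1 the same change had made it a weaker one. The two steps run in opposite directions, and the gap between them is larger than repeat measurements would explain: the same change on two cores in this assay, a 10-fold higher number (1.00 log units; beyond the scatter) from compound 1 to compound 2 and a 3.7-fold lower number (0.57 log units; beyond the scatter) from compound 3 to compound 4, 37-fold (1.57 log units) apart, beyond the scatter of two such steps In this series, then, the result of this change on one core gave no safe guide to its result on the other, but two pairs cannot show which difference between the cores sets the direction, or give a rule for any further core.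

The compounds shown leave open how other groups at this same place, such as fluoro or an amine, would compare with chloro and methoxy on each core. They also leave open which way the step would run on a third core.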